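A few compounds are considered here, and "the series" means these few. Any claim that something is new, unique, unknown or untested is made for them only; others in the source may bear on it.

Compound 1 `CC(C)C(c1ccc(-c2ccc3cccc(F)c3c2)[nH]c1=O)N1CCCCS1(=O)=O`: 0.0733 h
Compound 2 `CC(C)C(c1cnc(N)s1)c1ccc(-c2ccc3cccc(F)c3c2)[nH]c1=O`: 0.08 h
Compound 3 `CC(C)C(c1ccc(-c2ccc3cccc(F)c3c2)[nH]c1=O)N1CCNC1=O`: not yet measured

In an ADME assay on microsomes from liver (Mus musculus) for metabolic stability (a lower number here means that the compound disappears faster, a higher number that the compound lasts longer), compound 2 gives 0.08 h, level with compound 1 at 0.0733 h. For the measured compounds named here, the single measured step, a 1.1-fold higher number from compound 1 to compound 2 (0.04 log units; within the scatter), stays within the usual scatter.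

Compound 3 differs from compound 2 in one place: 2-oxoimidazolidin-1-yl in place of 2-amino-1,3-thiazol-5-yl on a saturated chain carbon bound to an aromatic carbon and a saturated chain carbon. In counted terms, (2-oxoimidazolidin-1-yl in place of 2-amino-1,3-thiazol-5-yl on a saturated chain carbon bound to an aromatic carbon and a saturated chain carbon).

The measured step replaced one ring group with another on that same carbon, and the half-life did not move beyond the scatter. One step is thin evidence, and neither measured compound carries the entering group, so the range stays wide. The estimated step is no change at the digits printed from compound 2 to compound 3 (within the scatter), which means no change beyond the scatter is expected. The expected half-life of compound 3 is 0.08 h, with an estimated range of 0.04 h to 0.17 h.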

Compound 3, half-life: 0.682 h
Beside the measured number, compound 3's estimate is 8.5-fold (0.93 log units) below it; measured number above the stated range.
By their numbers in this assay, from the lowest: compounds 1 and 2 (each within the scatter of the next); then compound 3.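

In this assay, this position proves able to change the half-life: the earlier swap of one ring group for another on the saturated chain carbon stayed within the scatter, whereas 2-oxoimidazolidin-1-yl gives an 8.5-fold higher number from compound 2 to compound 3 (0.93 log units; beyond the scatter). The same group also gives a 9.3-fold higher number from compound 1 to compound 3 (0.97 log units; beyond the scatter), so the rise appears against both other groups shown at this carbon. Both groups that leave contain sulfur and the entering group does not, but three compounds can only note this difference, not establish that it matters.

No measurement here explains why the half-life rises. As far as these compounds go, it remains open whether the longer half-life would persist with pyrrolidin-1-yl, which has no carbonyl, or with a carboxylic acid on this carbon.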